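The source may hold more compounds than are shown below. What is called first, only, known or untested is meant among the compounds shown, and "the series" means these compounds.

- compound 1 `CN(C)CC/C=C/C(=O)Nc1ccccc1`: 7.38 h
- compound 2 `O=C(/C=C/C(F)(F)F)Nc1ccccc1`: 0.267 h

Among the compounds with values here, in an ADME assay for pharmacokinetics, read by LC-MS, in phosphate buffer, with a stated time of 120 min, at pH 7.4, tested at 1 uM, in the presence of a further agent that is not named here (a lower number here means that the compound disappears faster, a higher number that the compound lasts longer), compound 1 gives 7.38 h, the higher of the only two numbers available, and compound 2 gives 0.267 h. The next molecule is compound 3 `CCN(CC)C/C=C/C(=O)Nc1ccccc1`, and the change is diethylamino in place of (dimethylamino)methyl on a saturated chain carbon bound to a double-bonded chain carbon.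

Within the data shown here, only one measured step bears on this, and only loosely. It was large: a 28-fold lower number from compound 1 to compound 2 (1.44 log units; beyond the scatter). That step swapped the amine-bearing chain for trifluoromethyl, whereas compound 3 still carries an amino group, so a far smaller step is expected here, with no clear shift beyond the scatter. The estimated step is a 1.6-fold lower number from compound 1 to compound 3 (0.21 log units; within the scatter), a slight fall at most. For compound 3 the expected value is 4.5 h, with an estimated range of 1.5 h to 13 h.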

Compound 3, half-life: 2.83 h
Beside the measured number, compound 3's estimate is 1.6-fold (0.20 log units) above it; the range from low to high includes it.
By their numbers in this assay, from the lowest: compound 2; then compound 3; then compound 1.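

Even with an amino group kept, the number in this assay responds to what sits at this saturated chain carbon: diethylamino in place of (dimethylamino)methyl gives a 2.6-fold lower number from compound 1 to compound 3 (0.42 log units; beyond the scatter) and so moves beyond the usual scatter. This step is smaller than the one to trifluoromethyl, which was a 28-fold lower number from compound 1 to compound 2 (1.44 log units; beyond the scatter) on the earlier comparison, so the position tolerates this amine swap better, though it is not indifferent to it. The compounds shown offer no measured reason for the fall.

As far as these compounds go, this single swap alters both the chain leading to the nitrogen and the groups on that nitrogen, so it remains open which of the two matters. A dimethylamino group on the same saturated chain carbon, or a longer chain ending in diethylamino, would pull these two changes apart.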